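Stereocentre left undefined: where compound 3 should fall

The source may hold more compounds than are shown below. What is called first, only, known or untested is meant among the compounds shown, and "the series" means these compounds.

In a functional assay on the whole organism with Mus musculus as the target, with a stated time of 0.5 h (on this read-out lower numbers stand for an effect already at smaller amounts and higher numbers for an effect only at larger amounts of compound), compound 1 (`CC[C@]1(c2ccccc2)OC(=O)NC1=O`) gives 108 mg/kg, and compound 2 (`CC[C@@]1(c2ccccc2)OC(=O)NC1=O`) gives 42 mg/kg, the lower of the two numbers. Within the data shown here, the only measured step, a 2.6-fold lower number from compound 1 to compound 2 (0.41 log units; beyond the scatter), rests on (the fact that compounds 1 and 2 differ only in the configuration as drawn), and it is the one step that bears on what follows. Compound 3 (`CCC1(c2ccccc2)OC(=O)NC1=O`) is the next case: the two compounds have the same atoms and bonds; at least one stereo element is drawn with a configuration in one of them and without one in the other: 1 of 1 stereo elements differ; a stereocentre at a saturated ring carbon is drawn S in compound 2 and without a configuration in compound 3. With that stereocentre drawn without a configuration, and given the modest size of a 2.6-fold lower number from compound 1 to compound 2 (0.41 log units; beyond the scatter), the number for compound 3 is expected to lie between those of compound 1 and compound 2, nearer the lower one. The expected change is a small rise, a 1.4-fold higher number from compound 2 to compound 3 (0.15 log units; within the scatter), which may not clear the usual scatter. For compound 3 the estimated value is 60 mg/kg, with an expected range of 40 mg/kg to 95 mg/kg.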

Compound 3, dose for half-maximal effect: 39 mg/kg
Compound 3: the middle estimate sits 1.5-fold (0.19 log units) above what was measured; measured number below the stated range.
By their numbers in this assay, from the lowest: compounds 3 and 2 (each within the scatter of the next); then compound 1.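

In this assay the stereocentre drawn without a configuration reads with the S drawing and apart from the R drawing: a 1.1-fold lower number from compound 2 to compound 3 (0.03 log units; within the scatter), against a 2.8-fold lower number from compound 1 to compound 3 (0.44 log units; beyond the scatter). Compound 3 and compound 2 cannot be told apart on this read-out, while compound 1 stands apart from both, so leaving the configuration undefined opens no gap to compound 2. The only thing separating this pair is how the stereocentre is drawn: the fact that one of compounds 2 and 3 is drawn with a defined configuration and the other without, at the place where they differ

Whether compound 3 is a mixture of the two configurations, and in what proportion, cannot be read from its drawing. Also open, on these data alone, is whether a gap between the R and S drawings persists when a longer chain or an amine is carried at this stereocentre.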